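Swapping 2-acetamidoethyl for 1-carboxy-2-hydroxypropyl on the amine

The source may hold more compounds than are shown below. What is called first, only, known or untested is meant among the compounds shown, and "the series" means these compounds.

Among the compounds with values here, in a functional assay on HeLa cells (Homo sapiens) for antiproliferative activity, read by CCK-8 assay, with a stated time of 48 h (on this read-out higher numbers stand for weaker inhibition and lower numbers for stronger inhibition), compound 2 (`COc1ccc(/C=C\c2cc(OC)c(OC)c(OC)c2)cc1OCc1ccc(CNCCNC(C)=O)cc1`) gives 6400 nM as the only actual number so far. Compound 1 (`COc1ccc(/C=C\c2cc(OC)c(OC)c(OC)c2)cc1OCc1ccc(CN[C@H](C(=O)O)[C@H](C)O)cc1`) reads > 10000 nM in this assay, which is a limit of the assay and not a number. Compound 3 (`COc1ccc(/C=C\c2cc(OC)c(OC)c(OC)c2)cc1OCc1ccc(CN[C@H](C(=O)O)[C@@H](C)O)cc1`) departs from compound 2 by this change: 1-carboxy-2-hydroxypropyl in place of 2-acetamidoethyl on an amine nitrogen. Within the data shown here, the one measured step bearing on this runs the opposite way, with the same two named groups: an at least 1.5-fold lower number from compound 1 to compound 2 (0.19 log units; that floor lies within the scatter). Read in reverse, that step from compound 1 points toward a higher number for compound 3, though its true size stays open. The expected change is a 1.9-fold higher number from compound 2 to compound 3 (0.27 log units; within the scatter), toward weaker inhibition, and a reading that is only a limit would fit this expectation. Compound 3 is estimated at 12000 nM with 4500 nM to 30000 nM as the expected range.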

Compound 3, half-maximal inhibitory concentration: > 10000 nM
Compound 3 gave a limit, no number (the forecaster's own chance of this, stated with the estimate: 60%); the middle value is on the limit's open side.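

In this assay the reading of compound 3 is a limit and not a number, so 1-carboxy-2-hydroxypropyl on this amine nitrogen has now given a limit in both of its drawn configurations, the new point being: the fact that compounds 1 and 3 differ only in the configuration as drawn. Against 2-acetamidoethyl, the change gives an at least 1.5-fold higher number from compound 2 to compound 3 (0.19 log units; that floor lies within the scatter), and that figure is only a floor, so the true size of the step remains unknown. The step between the two stereoisomers cannot be read, because neither has a number: the limit of > 10000 nM in this assay, at which 2 of the 3 values shown sit.

Going by these compounds, whether the changed stereocentre affects the reading at all therefore remains open. Also open, on these data alone, is how a carboxymethyl group, a 2-hydroxyethyl group or a longer chain ending in an acetamide would read on this amine nitrogen, which could separate the contributions of the carboxylic acid and the hydroxyl.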